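Acyl versus methylene on the ring nitrogen: compound 4

The source may hold more compounds than are shown below. What is called first, only, known or untested is meant among the compounds shown, and "the series" means these compounds.

Compound 3 `CCCCNc1nc(N)nc2c1CN(Cc1ccco1)CC2` gives 0.08 uM in an assay on HEK293 cells for agonist activity at Toll-like receptor 8 (Homo sapiens), read by a luciferase reporter, with a stated time of 6 h (on this read-out lower numbers stand for an effect already at smaller amounts and higher numbers for an effect only at larger amounts of compound), and stands second highest of the three numbers. Nearest is compound 1 `CCCCNc1nc(N)nc2c1CN(Cc1ccccc1)CC2` with 0.06 uM, within the scatter of compound 3; furthest is compound 2 `CCCCNc1nc(N)nc2c1CN(C(=O)c1ccccc1)CC2` with 1.4 uM, an 18-fold lower number from compound 2 to compound 3 (1.24 log units; beyond the scatter). The change to compound 4 `CCCCNc1nc(N)nc2c1CN(C(=O)c1ccncc1)CC2` is (pyridin-4-yl)carbonyl in place of (furan-2-yl)methyl on an amine nitrogen in a ring. Going by the values given here, two measured steps bear on it: a 23-fold higher number from compound 1 to compound 2 (1.37 log units; beyond the scatter) and an 18-fold lower number from compound 2 to compound 3 (1.24 log units; beyond the scatter), both large, both separating a carbonyl-linked ring from a methylene-linked ring on that nitrogen. Swapping the ring alone, a 1.3-fold higher number from compound 1 to compound 3 (0.12 log units; within the scatter), stayed within the scatter. Among the compounds with values here, no measured step tests a pyridine ring. A large rise in this assay is therefore expected for compound 4, a 19-fold higher number from compound 3 to compound 4 (1.27 log units; beyond the scatter). Compound 4 is estimated at 1.5 uM, range 0.5 uM to 5 uM.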

Compound 4, minimum effective concentration: > 25 uM
Compound 4: only a limit was reported; the forecaster's own chance of this, stated with the estimate: 10%; middle value at least 16-fold (1.22 log units) from the limit.
By their numbers in this assay, from the lowest: compounds 1 and 3 (each within the scatter of the next); then compound 2. At a limit, above all of these: compound 4.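

Compound 4 gives only a limit in this assay: the limit of > 25 uM in this assay, at which 1 of the 4 values shown sits. On the carbonyl link the ring itself now counts, with an at least 17-fold higher number from compound 2 to compound 4 (1.25 log units; beyond the scatter) for the pyridin-4-yl ring alone, whereas on the methylene link a 1.3-fold higher number from compound 1 to compound 3 (0.12 log units; within the scatter) stayed within the scatter. Ring and link changed together give an at least 310-fold higher number from compound 3 to compound 4 (2.49 log units; beyond the scatter) and an at least 410-fold higher number from compound 1 to compound 4 (2.61 log units; beyond the scatter) as the widest steps at this amine nitrogen in a ring.

On these data alone, whether the pyridin-4-yl ring is tolerated on a methylene link remains open. A (pyridin-4-yl)methyl group on that nitrogen would separate the ring from the carbonyl.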